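The source may hold more compounds than are shown below. What is called first, only, known or untested is meant among the compounds shown, and "the series" means these compounds.

Working notes on a small set of four close analogues. Compound 1 `Cc1cccc(C2=NC(c3ccccc3)CO2)c1` and compound 3 `Cc1ccc(C2=NC(c3ccccc3)CO2)cc1` are built from the same atoms joined differently; the difference between the two cores is not broken down here. Compound 2 `Clc1cccc(C2=NC(c3ccccc3)CO2)c1` is compound 1 with a (chloro in place of methyl on an aromatic carbon). In a physicochemical assay for lipophilicity (on this read-out higher numbers stand for higher lipophilicity and lower numbers for lower lipophilicity), compound 1 gives 4.11, compound 2 gives 4.44 and compound 3 gives 4.11. Among the compounds with values here, the one counted step, a number 0.33 log units higher from compound 1 to compound 2 (beyond the scatter), is modest yet beyond the scatter. Compound 3 stands level with compound 1 at the digits read, and the two together sit under compound 2 in this assay. Compound 4 `Clc1ccc(C2=NC(c3ccccc3)CO2)cc1` has not yet been measured in this assay; relative to compound 3 it carries a (chloro in place of methyl on an aromatic carbon). This is the same kind of change as that from compound 1 to compound 2, but the place differs: meta to a large group in the measured pair, para to a large group here. Within the data shown here, with only one measured example of this change, the expectation rests on the step of a number 0.33 log units higher from compound 1 to compound 2 (beyond the scatter). For compound 4 the expected step is a number 0.33 log units higher from compound 3 to compound 4 (beyond the scatter). Compound 4 is therefore estimated at 4.44, with a plausible range from 4.2 to 4.7.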

Compound 4, partition coefficient: 4.48
Estimate against measurement, compound 4: 0.04 log units below; measured number inside the range.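

Chloro in place of methyl on an aromatic carbon gives a number 0.37 log units higher from compound 3 to compound 4 (beyond the scatter) in this assay and the same change gives a number 0.33 log units higher from compound 1 to compound 2 (beyond the scatter) on the other core, so in these two pairs the step carries from one core to the other with the same direction and the same modest size. This rests on two pairs and one change, and it does not show that the step would hold on any further core, at any other place on the ring or in any other read-out. Nothing shown here bears on why the step has this size.

The compounds shown leave open whether other groups in this place, such as an amine, a carboxylic acid or a longer chain, would follow the same step from one core to the other. They also leave open how the two cores compare once the group para to a large group is something other than methyl or chloro.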